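Methyl Steps on Two Related Cores

A few compounds are considered here, and "the series" means these few. Any claim that something is new, unique, unknown or untested is made for them only; others in the source may bear on it.

Three compounds of this series have measured values. Compound 3 `COc1cccc(-c2cc(O)c3c(C)ccnc3n2)c1` gives 51.3 nM in a functional assay on 786-0 cells (Homo sapiens); a higher number here means a weaker inhibitor of growth, a lower number a stronger inhibitor of growth. Compound 1 `COc1cccc(-c2cc(O)c3c(C)cc(C)nc3n2)c1` gives 437 nM in this assay. These two differ in one place: methyl in place of hydrogen on an aromatic carbon. That single change produced an 8.5-fold higher number from compound 3 to compound 1 (0.93 log units; beyond the scatter). Compound 2 `COc1ccccc1-c1cc(O)c2cccnc2n1` gives 36300 nM in this assay, the highest number of the three, its steps to both others being beyond the scatter; the difference between its core and the core of compound 3 is not broken down here.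

Compound 4 `COc1ccccc1-c1cc(O)c2cc(C)cnc2n1` has not yet been measured. It differs from compound 2 by methyl in place of hydrogen on an aromatic carbon. For the measured compounds named here, this is the same kind of change as the one from compound 3 to compound 1, but not the same change: in compound 4 the methyl enters two atoms from the ring nitrogen on a core carrying no other methyl, whereas in compound 1 it enters next to the ring nitrogen and meta to a methyl group. Going by the values given here, the one measured step of this kind weakened growth inhibition, so compound 4 is expected to show a 1.5-fold higher number from compound 2 to compound 4 (0.18 log units; within the scatter), a step read as weaker than an 8.5-fold higher number from compound 3 to compound 1 (0.93 log units; beyond the scatter) given the different place and the already high starting value of compound 2. The estimate for compound 4 is 55000 nM. For compound 4 the expected range runs from 12000 nM to 250000 nM.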

Compound 4, concentration for 50% growth inhibition: 41700 nM
Compound 4: the middle estimate sits 1.3-fold (0.12 log units) above what was measured, within the range that was stated.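

In this assay the new step reads a 1.1-fold higher number from compound 2 to compound 4 (0.06 log units; within the scatter), so on this core methyl in place of hydrogen on an aromatic carbon leaves the number within the scatter, and this pair cannot be told apart. Set beside the earlier step, the same kind of change does not carry its size from one core to the other: the same change on two cores in this assay, an 8.5-fold higher number (0.93 log units; beyond the scatter) from compound 3 to compound 1 and a 1.1-fold higher number (0.06 log units; within the scatter) from compound 2 to compound 4, 7.4-fold (0.87 log units) apart, beyond the scatter of two such steps. This shows that a step seen on one core in this series cannot simply be transferred to the other, but it does not show what sets the two steps apart, since they differ both in the core and in the place the methyl enters, and with one step on each core these two cannot be separated.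

Open, on these data alone, is whether the methyl placed two atoms from the ring nitrogen on the core of compound 3 would give a step like the one on the core of compound 2, a comparison that would separate place from core. Also open, as far as these compounds go, is what a group other than methyl, such as an amine, a carboxylic acid or a longer chain, would do at the place taken by the methyl in compound 4.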